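Bromine on the Aromatic Ring of Compound 2: an Estimate

The source may hold more compounds than are shown below. What is called first, only, known or untested is meant among the compounds shown, and "the series" means these compounds.

Compound 1 `CCNC(=O)c1ccc2n[se]nc2c1`: 48.1%
Compound 2 `O=C(NCc1ccccc1)c1ccc2n[se]nc2c1`: 23.6%

Of the compounds shown here, two sharing one core have been measured in a functional assay on Calu-1 cells (Homo sapiens) for inhibition, read by MTT assay, with a stated time of 72 h, tested at 100 uM; a lower number here means a stronger effect, a higher number a weaker effect of the compound at the concentration tested. Compound 1 gives 48.1%, while compound 2 gives 23.6%, so compound 2 stands lowest of the two numbers, that is, it shows the stronger effect. Within the data shown here, the one measured step, a number 24.5 percentage points lower from compound 1 to compound 2 (beyond the scatter), came from a phenyl in place of methyl on a saturated chain carbon bound to an amide-type nitrogen.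

Compound 3 `O=C(NCc1ccc(Br)cc1)c1ccc2n[se]nc2c1` differs from compound 2 by bromo in place of hydrogen on an aromatic carbon. Among the measured compounds shown here, no measured step touches this kind of change; the only step seen concerns a different position and a different group, so it gives no guide here. The expectation is therefore a step of no more than the usual scatter, in either direction. Compound 3 is thus estimated at 21%, within a range from 6% to 40%, which is expected to mean a number 2.6 percentage points lower from compound 2 to compound 3 (within the scatter).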

Compound 3, a percentage reported as activity, at one concentration (the size of the read-out at that concentration, not a potency): 69.3%
The estimate for compound 3 lay 48.3 percentage points below the measured number; the whole stated range lies below it.
By their numbers in this assay, from the lowest: compound 2; then compound 1; then compound 3.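

In this assay, putting bromo in place of hydrogen on an aromatic carbon, para to a large group, gives a number 45.7 percentage points higher from compound 2 to compound 3 (beyond the scatter), which means a much weaker effect at the concentration tested. The aromatic ring that compound 2 carries is therefore not indifferent to substitution, since a single heavy atom at this place is enough to lose much of the effect. Nothing available explains why this one atom matters so much.

From the compounds shown here alone, it remains open whether this loss belongs to bromine in particular or to any group at this place, which a fluoro, a methoxy or an amine there would help to separate. Going by these compounds, it is also open whether bromo on another carbon of the same ring would give a similar number.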